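This account rests on a few compounds, and the source may have more. Where it says the series, first, only, none or still open, it means among the compounds named here.

Three compounds built on a two-ring core were tested in a functional assay on RXF 393 cells (Homo sapiens) for cytotoxicity, read by sulforhodamine B assay, with a stated time of 48 h; a higher number here means a weaker inhibitor of growth, a lower number a stronger inhibitor of growth. Compound 1 `ClCc1ccccc1Cn1cnc2c(Cl)nc(Cl)nc21` gives 490 nM in this assay. Compound 2 `ClCc1ccccc1Cn1cnc2c(Cl)ncnc21` carries one chloro group fewer and gives 2340 nM in this assay. The structural difference from compound 2 to compound 1 is chloro in place of hydrogen on an aromatic carbon, and the measured step is a 4.8-fold lower number from compound 2 to compound 1 (0.68 log units; beyond the scatter).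

Compound 3 `ClCc1ccccc1Cn1cnc2ncnc(Cl)c21` contains the same atoms as compound 2, joined differently, so the two cores are not the same; how they differ is not broken down here. In this assay compound 3 gives 6540 nM, the highest of the three numbers.

Compound 4 `ClCc1ccccc1Cn1cnc2nc(Cl)nc(Cl)c21` has not yet been measured. It differs from compound 3 by chloro in place of hydrogen on an aromatic carbon. The description of the place is the same word for word as for the earlier change, so this is the same change carried out on the core of compound 3 rather than on the core of compound 2.

Among the measured compounds shown here, the step is expected to be a 4.4-fold lower number from compound 3 to compound 4 (0.64 log units; beyond the scatter), which rests on a single earlier example, because a 4.8-fold lower number from compound 2 to compound 1 (0.68 log units; beyond the scatter) is the only measured instance of this change, and the core it was made on is not identical. For compound 4 the expected value in this assay is 1500 nM, with a likely range from 600 nM to 4000 nM.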

Compound 4, concentration for total growth inhibition: 1900 nM
Beside the measured number, compound 4's estimate is 1.3-fold (0.10 log units) below it, and the stated range covers the measured number.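

In this assay, putting the chloro group in place of hydrogen on the core of compound 3 gives a 3.4-fold lower number from compound 3 to compound 4 (0.54 log units; beyond the scatter) and so moves the number in the same direction as the earlier example. On these two cores, the change therefore carried over in direction, and its size held as well: the same change on two cores in this assay, a 4.8-fold lower number (0.68 log units; beyond the scatter) from compound 2 to compound 1 and a 3.4-fold lower number (0.54 log units; beyond the scatter) from compound 3 to compound 4, 1.4-fold (0.14 log units) apart, within the scatter of two such steps

This supports treating the step as transferable between these two related cores, but only for this one group, on the aromatic carbon between two ring nitrogen atoms, and only in growth inhibition of this one cell line. Two cores are too few to establish a rule for the wider series, and the matching steps do not explain why the chloro group lowers the number.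

The compounds shown leave open whether an amine or a methoxy group in place of that same hydrogen would also lower the number, or whether the effect is particular to chloro. They also leave open what happens when the chloromethyl group shared by all four compounds gives way to a hydroxymethyl group or a longer chain.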